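Working notes on a tert-butoxycarbonyl removal step

This account rests on a few compounds, and the source may have more. Where it says the series, first, only, none or still open, it means among the compounds named here.

Measured compounds in a functional assay on MCF7 cells (Homo sapiens) for inhibition, read by MTT assay, with a stated time of 72 h; a higher number here means a weaker inhibitor, a lower number a stronger inhibitor:

compound 1 `CC(C)(C)OC[C@@H](NC(=O)c1cc(Cl)ccc1OCCNC(=O)OC(C)(C)C)C(=O)Nc1ccc([N+](=O)[O-])cc1Cl`, > 10000 nM, which is a limit of the assay rather than a number.
compound 2 `CC(C)(C)OC[C@@H](NC(=O)c1cc(Cl)ccc1OCCN)C(=O)Nc1ccc([N+](=O)[O-])cc1Cl`, 1620 nM.
compound 3 `CC(C)[C@H](NC(=O)c1cc(Cl)ccc1OCCNC(=O)OC(C)(C)C)C(=O)Nc1ccc(C(F)(F)F)cc1Cl`, > 10000 nM, again a limit of the assay rather than a number.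

Compound 1 and compound 3 share the same kind of side chain but differ in more than one place; the difference between the two cores is not broken down here. Among the measured compounds shown here, the one change that is made twice is hydrogen in place of tert-butoxycarbonyl on an amine nitrogen. Between the measured pair it gives an at least 6.1-fold lower number from compound 1 to compound 2 (0.79 log units; beyond the scatter). This is a lower bound, since the limit of > 10000 nM in this assay, at which 2 of the 3 values shown sit, sets where compound 1 sits.

Compound 4 `CC(C)[C@H](NC(=O)c1cc(Cl)ccc1OCCN)C(=O)Nc1ccc(C(F)(F)F)cc1Cl` is not yet measured. It arises from compound 3 by hydrogen in place of tert-butoxycarbonyl on an amine nitrogen, with the place of change identical word for word to the first pair, so this is the same change on the core of compound 3. Compound 3 itself sits at the limit, so only the direction and a floor for the step can be carried over. Compound 4 is therefore expected to show an at least 4.0-fold lower number from compound 3 to compound 4 (0.60 log units; beyond the scatter) in this assay, a step taken beside an at least 6.1-fold lower number from compound 1 to compound 2 (0.79 log units; beyond the scatter) and resting on that single measured pair, with the caveat that compound 3 offers only a limit to start from. For compound 4 the estimate is 2500 nM, most likely between 600 nM and 10000 nM.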

Compound 4, half-maximal inhibitory concentration: > 10000 nM
Compound 4: only a limit was reported; the forecaster's own chance of this, stated with the estimate: 35%; at least 4.0-fold (0.60 log units) between middle value and limit.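

In this assay compound 4 gives > 10000 nM, which is a limit and not a number. Compound 3 also stands at a limit, so no step from compound 3 to compound 4 can be read: the limit of > 10000 nM in this assay, at which 3 of the 4 values shown sit.

The compounds shown leave open whether hydrogen in place of tert-butoxycarbonyl on an amine nitrogen shifts the number at all on the core of compound 3.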